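Efficacy at the Prostaglandin D2 Receptor: From Amine to Methyl

A few compounds are considered here, and "the series" means these few. Any claim that something is new, unique, unknown or untested is made for them only; others in the source may bear on it.

Compound 1 `Nc1nc(-c2ccc(Cl)cc2)c(CC(=O)O)s1` carries an amino group on the shared core, and in an in vitro functional assay on HEK285-7 cells for antagonist activity at prostaglandin D2 receptor 2 (Homo sapiens), read by BRET and beta-arrestin recruitment (on this read-out lower numbers stand for smaller maximal responses and higher numbers for larger maximal responses), compound 1 gives 50%. Compound 2 `O=C(O)Cc1sc(NCc2ccccc2)nc1-c1ccc(Cl)cc1` gives 30% in this assay, the lowest of the two measured numbers, its nearest neighbour being compound 1 at a number higher by a step beyond the scatter. For the measured compounds named here, the only step measured so far, a number 20 percentage points lower from compound 1 to compound 2 (beyond the scatter), is the one that bears here. Compound 3 `Cc1nc(-c2ccc(Cl)cc2)c(CC(=O)O)s1` differs from compound 2 by methyl in place of benzylamino on an aromatic carbon. Going by the values given here, no measured step exchanges a benzylamino group for a methyl group, so the direction is uncertain; the measured step downward on adding benzyl is the sole guide, and removing that benzylamino group plausibly returns the maximal response partway toward the value of compound 1. Compound 3 is therefore expected to give 40%, within 15% to 65%. This amounts to an expected step of a number 10 percentage points higher from compound 2 to compound 3 (within the scatter).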

Compound 3, largest response reached (reported as efficacy), in percent of the reference or control that the assay uses: 50%
Beside the measured number, compound 3's estimate is 10 percentage points below it; measured number inside the range.
By their numbers in this assay, from the lowest: compound 2; then compounds 1 and 3 (each within the scatter of the next).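

In this assay the exchange of benzylamino for methyl on this aromatic carbon gives a number 20 percentage points higher from compound 2 to compound 3 (beyond the scatter) and so the lower maximal response of compound 2 does not carry over to compound 3. Methyl in place of amino on the same carbon gives no change at the digits printed from compound 1 to compound 3 (within the scatter) and on this read-out compound 1 and compound 3 cannot be told apart. Of the three groups seen at this position, only benzylamino stands apart, and a nitrogen on this carbon is not required to keep the number at the level of compound 1.

No data shown here explain these differences. As far as these compounds go, it remains open whether an ethyl group, a longer alkyl chain or a benzyl group joined directly to this carbon would fall with compound 2 or with compound 1 and compound 3.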